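The source may report more compounds than this note shows. Statements on the series, on what has been measured and on what is new or still open speak of the compounds shown alone.

In a functional assay on MCF7 cells (Homo sapiens) for antiproliferative activity, read by MTT assay (a higher number here means a weaker inhibitor, a lower number a stronger inhibitor), compound 2 `CCCC/C=C\CCCCCCCCCc1cc(=O)c2c(O)c(C)c(OCOC)cc2o1` reaches only a limit, > 67200 nM, and not an exact number. In this assay, compound 1 `CCCCC/C=C\C/C=C\CCCCCCCc1cc(=O)c2c(O)c(C)c(OCOC)c(C)c2o1` likewise gives only a limit, > 84100 nM. Compound 3 `CCCCC/C=C\C/C=C\CCCCCCCc1cc(=O)c2c(O)c(C)c(OCOC)cc2o1` differs from compound 2 in its long side chain, with deca-1,4-dien-1-yl in place of oct-3-en-1-yl on a saturated chain carbon, seven bonds along the chain from an aromatic carbon. Among the compounds with values here, no measured step between related compounds is available as a guide. The expected step that the limit leaves unreadable from compound 2 to compound 3 is none beyond the usual scatter, in either direction. For compound 3 the estimated value is 70000 nM, with an expected range of 30000 nM to 130000 nM.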

Compound 3, half-maximal inhibitory concentration: > 67200 nM
Compound 3: no number, only a limit (the forecaster's own chance of this, stated with the estimate: 75%); the middle value is on the limit's open side.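

Within the data shown here, compound 1, compound 2 and compound 3 each give only a limit in this assay, so no step between them can be read. From the compounds shown here alone, the true strength of each compound in this assay remains open, as does any effect of the side-chain or methyl changes.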